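Phenyl for propyl: cytotoxicity expectation for compound 3

This account rests on a few compounds, and the source may have more. Where it says the series, first, only, none or still open, it means among the compounds named here.

Among the compounds with values here, in an ADME assay on MRC5 cells (Homo sapiens), read by MTT assay (a lower number here means that less compound is tolerated, a higher number that more compound is tolerated), compound 2 `CCCc1cc2cn(C3CC(CO)N(C)O3)c(=O)nc2o1` gives 31300 nM, the only number among the values shown. Compound 1 `CN1OC(n2cc3ccoc3nc2=O)CC1CO` sits at a limit, > 250000 nM, in this assay. Within the data shown here, the single measured step, an at least 7.9-fold lower number from compound 1 to compound 2 (0.90 log units; beyond the scatter), rests on the limit of > 250000 nM in this assay, at which 1 of the 2 values shown sits, and tells a propyl change, not an aryl one. Compound 3 `CN1OC(n2cc3cc(-c4ccccc4)oc3nc2=O)CC1CO` carries phenyl in place of propyl on an aromatic carbon. Among the measured compounds shown here, no measured step bears directly on it, so the expected step of a 1.6-fold lower number from compound 2 to compound 3 (0.19 log units; within the scatter) is small, leaning to a lower number. Compound 3 is estimated at 20000 nM, between 7000 nM and 60000 nM.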

Compound 3, half-maximal cytotoxic concentration: 125000 nM
Beside the measured number, compound 3's estimate is 6.3-fold (0.80 log units) below it, and the stated range ends below it.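

On the aromatic carbon next to the ring oxygen, exchanging propyl for phenyl raises the number in this assay (a 4.0-fold higher number from compound 2 to compound 3 (0.60 log units; beyond the scatter)), so the number does not simply fall as the group here gains heavy atoms. Compound 1 gives a limit (> 250000 nM). Phenyl against hydrogen therefore has only a floor (an at least 2.0-fold lower number from compound 1 to compound 3 (0.30 log units; that floor lies within the scatter)), and its true size stays unknown: the limit of > 250000 nM in this assay, at which 1 of the 3 values shown sits.

Open, from the compounds shown here alone, is how a longer chain, a cyclohexyl ring or a phenyl carrying an amine would read at this carbon. With only propyl and phenyl in hand, the effect of an aromatic ring cannot be separated from that of group size.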